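Piperazine variants on the shared core in the agonist readout

A few compounds are considered here, and "the series" means these few. Any claim that something is new, unique, unknown or untested is made for them only; others in the source may bear on it.

Compound 1 `Cc1cnc(CN(C)C[C@H]2Cc3c(cccc3N3CCNCC3)CN2)c(C)c1` in a functional assay on CCRF-CEM cells for agonist activity at C-X-C chemokine receptor type 4 (Homo sapiens), read by calcium flux, with a stated time of 25 min (a higher number here means that more compound is needed for the effect, a lower number that less compound is needed), gives only the assay limit > 30000 nM.
Compound 2 `CN(C[C@H]1Cc2c(cccc2N2CCN(C3CC3)CC2)CN1)[C@H]1CCCc2cccnc21` in this assay gives only the assay limit > 30000 nM.
Compound 3 `CN(C[C@H]1Cc2c(cccc2N2CCN3CCC[C@H]3C2)CN1)[C@H]1CCCc2cccnc21` in this assay gives only the assay limit > 30000 nM.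

Among the compounds with values here, compound 3 therefore stands at a limit, not at a number; every value so far sits at the limit of > 30000 nM in this assay, at which 3 of the 3 values shown sit. The next compound, compound 4 `CN1CCN(c2cccc3c2C[C@H](CN(C)[C@H]2CCCc4cccnc42)NC3)CC1`, arises through (a group of 7 heavy atoms (5 carbon, 2 nitrogen; one six-membered non-aromatic ring with 2 hetero atoms) in place of a group of 9 heavy atoms (7 carbon, 2 nitrogen; one five-membered non-aromatic ring with 1 hetero atom, one six-membered non-aromatic ring with 2 hetero atoms), on an aromatic carbon). Within the data shown here, the only related measured step, a step that the two limits leave unreadable from compound 2 to compound 3, is itself unreadable, so no measured step gives a size or direction for this change. Compound 4 is expected to stay at the limit, with an estimate of 40000 nM (range 10000 nM to 150000 nM). The expected step that the limit leaves unreadable from compound 3 to compound 4 is accordingly not readable beyond the scatter.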

Compound 4, half-maximal effective concentration: > 30000 nM
Compound 4 ended at the assay's limit (the forecaster's own chance of this, stated with the estimate: 80%); the middle value does not contradict the limit.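

Compound 4 sits at the assay limit, as do compound 2 and compound 3, so neither new step can be read: the limit of > 30000 nM in this assay, at which 4 of the 4 values shown sit.

The compounds shown leave open which change on the shared core, if any, gives a measurable value.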